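A few compounds are considered here, and "the series" means these few. Any claim that something is new, unique, unknown or untested is made for them only; others in the source may bear on it.

Measured compounds in a functional assay on HCT-116 cells (Homo sapiens) for cytotoxicity, read by CellTiter-Glo, with a stated time of 5 days; a lower number here means a stronger inhibitor, a higher number a weaker inhibitor:
compound 1 `COc1ccc(Cn2nc(Nc3cc(C)[nH]n3)c3ccccc3c2=O)cc1`, 1200 nM
compound 2 `CC(=O)Nc1ccc(Cn2nc(Nc3cc(C)[nH]n3)c3ccccc3c2=O)cc1`, 4200 nM
compound 3 `Cc1cc(Nc2nn(Cc3ccc([N+](=O)[O-])cc3)c(=O)c3ccccc23)n[nH]1`, 1400 nM

Compound 1 gives the lowest of the three numbers in this assay; compound 3 sits within the scatter of it, and compound 2 is the furthest, a 3.5-fold higher number from compound 1 to compound 2 (0.54 log units; beyond the scatter). The other steps are a 1.2-fold higher number from compound 1 to compound 3 (0.07 log units; within the scatter) and a 3.0-fold lower number from compound 2 to compound 3 (0.48 log units; beyond the scatter).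

Compound 4 `Cc1cc(Nc2nn(-c3ccc(F)cc3)c(=O)c3ccccc23)n[nH]1` differs from compound 1 as follows: 4-fluorophenyl in place of 4-methoxybenzyl on an aromatic nitrogen. Among the compounds with values here, none of the measured steps bears directly on this change: all three vary only the group on the aromatic carbon of the 4-methoxybenzyl, and each of those steps is modest or within the scatter. On these data alone, the replacement of the whole 4-methoxybenzyl by 4-fluorophenyl is untested, so the expected step is uncertain in direction. A modest weakening is estimated, a 2.1-fold higher number from compound 1 to compound 4 (0.32 log units; beyond the scatter), and compound 4 is expected near 2500 nM with a range from 600 nM to 10000 nM.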

Compound 4, half-maximal inhibitory concentration: 800 nM
Estimate against measurement, compound 4: 3.1-fold (0.49 log units) above; measured number inside the range.
By their numbers in this assay, from the lowest: compounds 4, 1 and 3 (each within the scatter of the next); then compound 2.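

In this assay, the group on the aromatic nitrogen can be exchanged as a whole, not just varied on its aromatic carbon: a 1.5-fold lower number from compound 1 to compound 4 (0.18 log units; within the scatter). Going from 4-methoxybenzyl to 4-fluorophenyl removes the one hydrogen-bond acceptor and two heavy atoms, yet the step stays within the scatter. No supporting data bear on why this is so.

The compounds shown do not separate the fluorine from the loss of the benzyl form, which 4-fluorobenzyl or 4-methoxyphenyl would address. On these data alone, whether this nitrogen needs an aromatic ring at all remains open, and cyclohexyl or a plain alkyl chain would test that.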